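Swapping indazolyl for trifluoromethyl pyrazolyl on compound 2

The source may report more compounds than this note shows. Statements on the series, on what has been measured and on what is new or still open speak of the compounds shown alone.

Measured in an ADME assay on MDCK-II cells (Canis lupus familiaris) for permeability; on this read-out lower numbers stand for lower permeability and higher numbers for higher permeability:
Compound 1 `CCCC(Nc1ccc(-n2cc(C(F)(F)F)cn2)nc1)c1ccc(C(=O)NCCC(=O)O)cc1`: 4.6 10^-6 cm/s
Compound 2 `CCCC(Oc1ccc(-n2cc3ccccc3n2)cc1)c1ccc(C(=O)NCCC(=O)O)cc1`: 2.2 10^-6 cm/s
Compound 3 `CCCC(Nc1ccc(-n2cnc(C(F)(F)F)c2)cc1)c1ccc(C(=O)NCCC(=O)O)cc1`: 0.6 10^-6 cm/s

Compound 2 sits in the middle of these three numbers. Compound 1 stands above it and compound 3 below it, both gaps lying beyond the usual scatter of repeated measurements.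

Compound 4 `CCCC(Oc1ccc(-n2cc(C(F)(F)F)cn2)cc1)c1ccc(C(=O)NCCC(=O)O)cc1` has not yet been measured in this assay. It differs from compound 2 in one place: 4-(trifluoromethyl)-1H-pyrazol-1-yl in place of 2H-indazol-2-yl on an aromatic carbon. In words, 4-(trifluoromethyl)-1H-pyrazol-1-yl stands in place of 2H-indazol-2-yl on an aromatic carbon, para to a large group.

Among the measured compounds shown here, no two measured compounds differ in only one place, so the size of this change cannot be read directly from the data. The best clue is compound 1, which carries the same 4-(trifluoromethyl)-1H-pyrazol-1-yl group and gives 4.6 10^-6 cm/s, though it also differs from compound 4 elsewhere. On that slim evidence, a small upward move in this assay is expected, one that stays within the scatter. The expected change is a 1.2-fold higher number from compound 2 to compound 4 (0.07 log units; within the scatter). Compound 4 is estimated at 2.6 10^-6 cm/s, with an expected range from 1 10^-6 cm/s to 6 10^-6 cm/s.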

Compound 4, apparent permeability: 3.1 10^-6 cm/s
Estimate against measurement, compound 4: 1.2-fold (0.08 log units) below, within the range that was stated.
By their numbers in this assay, from the lowest: compound 3; then compounds 2, 4 and 1 (each within the scatter of the next, the first and the last beyond it).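

Among the compounds shown here, this is the first pair here that differs in only one place, so the size of this change can now be read directly: in this assay, putting 4-(trifluoromethyl)-1H-pyrazol-1-yl in place of 2H-indazol-2-yl gives a 1.4-fold higher number from compound 2 to compound 4 (0.15 log units; within the scatter). On this aromatic carbon, para to a large group, the two groups therefore cannot be told apart on this read-out, even though one brings a six-membered aromatic ring of carbon only and the other brings three fluorine atoms on a single carbon, at the same count of 9 heavy atoms. Nothing available explains why these two groups give numbers so close together.

Still open, from the compounds shown here alone, is whether this position tolerates groups of a very different kind, such as a small amine, a nitrile or a carboxylic acid, or whether one of those would move the number beyond the scatter. Also open, going by these compounds, is whether the same swap would read alike on the core of compound 1 or compound 3, as this single pair speaks only for the core of compound 2.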